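Taking Fluorine Away from Compound 3

The source may hold more compounds than are shown below. What is called first, only, known or untested is meant among the compounds shown, and "the series" means these compounds.

In a functional assay on HL-60 cells (Homo sapiens) for inhibition, with a stated time of 72 h (a higher number here means a weaker inhibitor, a lower number a stronger inhibitor), compound 3 (`CC(=O)OC[C@H]1O[C@@H](n2cc(C(F)(F)F)c(=O)[nH]c2=O)C[C@@H]1OC(C)=O`) gives 8.5 uM, within the scatter of compound 2 (`CC(=O)OC[C@H]1O[C@@H](n2cc(C(F)F)c(=O)[nH]c2=O)C[C@@H]1OC(C)=O`) at 14 uM. Compound 1 (`O=c1[nH]c(=O)n([C@H]2C[C@H](O)[C@@H](CO)O2)cc1CF`) gives > 1000 uM, which is a limit and not a number. Compound 4 (`CC(=O)OC[C@H]1O[C@@H](n2cc(CF)c(=O)[nH]c2=O)C[C@@H]1OC(C)=O`) has fluoromethyl in place of trifluoromethyl on an aromatic carbon. Among the compounds with values here, the one measured step that bears on this change is a 1.6-fold lower number from compound 2 to compound 3 (0.22 log units; within the scatter), where fluoro replaces a hydrogen on that same carbon. Within the data shown here, that single small step offers the only guide, so a modest shift toward a higher number in this assay is expected, staying within the scatter. The estimated step is a 1.8-fold higher number from compound 3 to compound 4 (0.25 log units; within the scatter). For compound 4 the estimate is 15 uM, with an expected range of 5 uM to 50 uM.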

Compound 4, concentration for 50% inhibition: 324 uM
Compound 4: middle estimate off by 22-fold (1.33 log units), on the low side; the measured number lies above the stated range.
By their numbers in this assay, from the lowest: compounds 3 and 2 (each within the scatter of the next); then compound 4. At a limit, above all of these: compound 1.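

Replacing trifluoromethyl with difluoromethyl on this aromatic carbon made no clear difference in this assay, yet fluoromethyl here gives a 38-fold higher number from compound 3 to compound 4 (1.58 log units; beyond the scatter) and a 23-fold higher number from compound 2 to compound 4 (1.36 log units; beyond the scatter), so compound 4 is clearly the weaker inhibitor. Across these three compounds, the effect of removing fluorine is therefore uneven, with the large change coming only when the carbon is left with a single fluorine. Nothing shown here explains this change. Still open, on these data alone, is how a plain methyl group or a nitrile on this carbon would compare with these three groups.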